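Methoxy added to the aryl tail of compound 2

A few compounds are considered here, and "the series" means these few. Any claim that something is new, unique, unknown or untested is made for them only; others in the source may bear on it.

Among the measured compounds shown here, compound 2 `N#Cc1c(NC(=O)CCc2ccccc2)sc2c1CCCC2` gives 290 nM in a functional assay on RKE cells for antagonist activity at Vasoactive intestinal polypeptide receptor 1 (Rattus norvegicus), read by HTRF and cAMP accumulation, with stated times of 10 min and 30 min (a lower number here means a stronger inhibitor, a higher number a weaker inhibitor), the lower of the two numbers measured so far; compound 1 `CC(=O)Nc1sc2c(c1C#N)CCCC2` gives 13000 nM, and the step of a 45-fold lower number from compound 1 to compound 2 (1.65 log units; beyond the scatter) is large. Compound 3 `COc1ccc(CCC(=O)Nc2sc3c(c2C#N)CCCC3)cc1` differs from compound 2 by methoxy in place of hydrogen on an aromatic carbon, on an aromatic carbon of a six-membered aromatic ring of carbon only, para to a large group. For the measured compounds named here, no measured step touches this ring; the only step of a 45-fold lower number from compound 1 to compound 2 (1.65 log units; beyond the scatter) concerns the chain and does not bear on it. A step within the scatter is therefore expected for compound 3, a 1.2-fold lower number from compound 2 to compound 3 (0.06 log units; within the scatter). Compound 3 is estimated at 250 nM, within 80 nM to 900 nM.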

Compound 3, half-maximal inhibitory concentration: 410 nM
Beside the measured number, compound 3's estimate is 1.6-fold (0.21 log units) below it; the measured number falls inside the stated range.
By their numbers in this assay, from the lowest: compounds 2 and 3 (each within the scatter of the next); then compound 1.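

In this assay, among the compounds shown here, the aromatic ring of the tail is probed for the first time, and phenyl to 4-methoxyphenyl gives a 1.4-fold higher number from compound 2 to compound 3 (0.15 log units; within the scatter) as its step. At this carbon, para to a large group, methoxy in place of hydrogen therefore leaves the number within the scatter, so this single substituent gives no sign of a gain or a loss. Nothing available explains this result.

Open, on these data alone, is whether an amine or a carboxylic acid at the same carbon would also stay within the scatter. Also open, as far as these compounds go, is how a longer chain between the carbonyl and the ring would read.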